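This account rests on a few compounds, and the source may have more. Where it says the series, first, only, none or still open, it means among the compounds named here.

Measured so far in a functional assay on BaF3 cells (Mus musculus) for inhibition, read by CCK-8 assay, with a stated time of 72 h; a lower number here means a stronger inhibitor of growth, a higher number a weaker inhibitor of growth:
compound 1 `CNc1cc(Oc2ccc(NC(=O)Nc3ccc(C)c(C(F)(F)F)c3)cc2)ncn1` — > 10000 nM
compound 2 `CCN1CCN(Cc2ccc(NC(=O)Nc3ccc(Oc4cc(NC(C)=O)ncn4)cc3)cc2C(F)(F)F)CC1` — 38 nM
compound 3 `Cc1ccc(NC(=O)Nc2ccc(Oc3cc(N4CCNC[C@H]4C)ncn3)cc2)cc1C(F)(F)F` — 9670 nM

The value of compound 1 is a limit of the assay, not a number. Among the two numbers, compound 3 has the highest; its nearest neighbour is compound 2, with a much lower number. Going by the values given here, the one single-point step on record, an at least 1.0-fold lower number from compound 1 to compound 3 (0.01 log units; that floor lies within the scatter), runs from a limit of > 10000 nM in this assay, at which 1 of the 3 values shown sits, and cannot be sized.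

Compound 4 `C=CC(=O)Nc1cc(Oc2ccc(NC(=O)Nc3ccc(C)c(C(F)(F)F)c3)cc2)ncn1` changes compound 3 by (vinylcarbonyl)amino in place of 2-methylpiperazin-1-yl on an aromatic carbon. Among the compounds with values here, no measured step covers an amide at this place against a piperazine; compound 2 carries an acetylamino there but also a different urea side, so its value shows only that an amide at that place can sit with a low number. A lower number is therefore expected for compound 4, though with wide uncertainty: estimate 1000 nM, range 100 nM to 10000 nM, a step of a 9.7-fold lower number from compound 3 to compound 4 (0.99 log units; beyond the scatter).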

Compound 4, concentration for 50% growth inhibition: 1940 nM
The estimate for compound 4 lay 1.9-fold (0.29 log units) below the measured number; the measured number falls inside the stated range.
By their numbers in this assay, from the lowest: compound 2; then compound 4; then compound 3. At a limit, above all of these: compound 1.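

Putting (vinylcarbonyl)amino in place of 2-methylpiperazin-1-yl on this aromatic carbon gives a modest change in this assay that lies beyond the scatter (a 5.0-fold lower number from compound 3 to compound 4 (0.70 log units; beyond the scatter)). Vinylcarbonyl in place of methyl on the nitrogen at this position also lowers the number (an at least 5.1-fold lower number from compound 1 to compound 4 (0.71 log units; beyond the scatter)). Compound 1 stands at a limit of the assay, so that step is only a floor: the limit of > 10000 nM in this assay, at which 1 of the 4 values shown sits.

Open, from the compounds shown here alone, is whether the lower number needs the vinyl double bond or follows from the amide alone. On this same core, a saturated propanoylamino group would separate the two.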